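The compounds below may be only part of what the source reports. "The series", "measured", "known", "first", "only" and "open" are said of these compounds alone.

Working notes on the series in an ADME assay on GES1 cells (Homo sapiens) for inhibition, read by MTT assay, with a stated time of 72 h; on this read-out lower numbers stand for stronger inhibition and higher numbers for weaker inhibition.

Compound 1 `Cc1ccc(CSc2nc3nc(C)cc(Nc4cc(-c5ccccc5)[nH]n4)n3n2)cc1` gives 36200 nM in this assay. Compound 2 `Cc1cc(Nc2cc(-c3ccccc3)[nH]n2)n2nc(SCc3ccc(C(F)(F)F)cc3)nc2n1` gives 42700 nM in this assay. The change between them is trifluoromethyl in place of methyl on an aromatic carbon and the step is a 1.2-fold higher number from compound 1 to compound 2 (0.07 log units; within the scatter).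

Compound 3 `Cc1ccc(Cn2ccc(Nc3cc(C)nc4nc(SCc5ccc(Br)cc5)nn34)n2)cc1` is recorded in this assay only as a limit, > 50000 nM, and not as a number. It is the compound that sits at the limit of > 50000 nM in this assay, at which 1 of the 3 values shown sits. How the core of compound 3 differs from the core of compound 1 is not broken down here.

Compound 4 `Cc1cc(Nc2ccn(Cc3ccc(C(F)(F)F)cc3)n2)n2nc(SCc3ccc(Br)cc3)nc2n1` is not yet measured in this assay. It differs from compound 3 by trifluoromethyl in place of methyl on an aromatic carbon, the same change that leads from compound 1 to compound 2, made at the same place. On the strength of that measured step, a 1.2-fold higher number from compound 1 to compound 2 (0.07 log units; within the scatter), which is within the scatter, the step from compound 3 to compound 4 is expected to be small as well, around a step that the limit leaves unreadable from compound 3 to compound 4. Since compound 3 is known only as a limit, compound 4 is expected to lie at or beyond it, estimated at 60000 nM, between 35000 nM and 150000 nM; a limit-only result is the most likely outcome.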

Compound 4, half-maximal inhibitory concentration: 30200 nM
Compound 4: middle estimate off by 2.0-fold (0.30 log units), on the high side; the whole stated range lies above it.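

In this assay, trifluoromethyl in place of methyl on the 4-methylbenzyl group gives an at least 1.6-fold lower number from compound 3 to compound 4 (0.21 log units; that floor lies within the scatter). Set beside the same change on the other core, the result does not settle whether the change carries over unaltered: the same change on two cores in this assay, a 1.2-fold higher number (0.07 log units; within the scatter) from compound 1 to compound 2 and an at least 1.6-fold lower number (0.21 log units; that floor lies within the scatter) from compound 3 to compound 4; the limit leaves it open whether they differ. From the compounds shown here alone, compound 3 is recorded only as a limit, > 50000 nM, and not as a number, so the full size of this step remains unknown; the data show neither that the change acts alike on the two cores nor that it acts differently.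

The compounds shown leave open how other groups would read in this assay at the place of this change, for example a nitrile, an amine or a carboxylic acid in place of methyl or trifluoromethyl. Also open, going by these compounds, is what a longer chain in place of the methyl on the shared core would do, on either the core of compound 1 or the core of compound 3.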